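Pyridazinone chain variants: from compound 1 to compound 4

A few compounds are considered here, and "the series" means these few. Any claim that something is new, unique, unknown or untested is made for them only; others in the source may bear on it.

Compound 1 `C/N=C(/NC#N)NCCCCCCn1nc(-c2ccccc2)ccc1=O` is known in a functional assay on the whole organism with Rattus norvegicus as the target (on this read-out lower numbers stand for an effect already at smaller amounts and higher numbers for an effect only at larger amounts of compound), only as a limit, > 100 mg/kg. Compound 2 `O=c1ccc(-c2ccccc2)nn1CCCCNC(=S)Nc1ccccc1` likewise gives in this assay the limit > 100 mg/kg. Compound 3 `CN(C)/C(=N/CCCn1nc(-c2ccccc2)ccc1=O)NC#N` gives 93.1 mg/kg in this assay. So compound 1 stands at the limit of > 100 mg/kg in this assay, at which 2 of the 3 values shown sit, with no number of its own. Compound 4 `CN(C)/C(=N/CCCCCn1nc(-c2ccccc2)ccc1=O)NC#N` differs from compound 1 by a group of 8 heavy atoms (4 carbon, 4 nitrogen; no ring) in place of a group of 8 heavy atoms (4 carbon, 4 nitrogen; no ring), on a saturated chain carbon, five bonds along the chain from an aromatic nitrogen. Among the measured compounds shown here, no measured pair shares this change, and compound 3 with the same entering group sits close to the limit, so no step beyond the scatter is expected in this assay. The step from compound 1 to compound 4 is estimated at a number no higher from compound 1 to compound 4 (the limit leaves the size open). Compound 4 is therefore expected at 100 mg/kg, within 40 mg/kg to 250 mg/kg, and a limit rather than a number is about as likely as not.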

Compound 4, dose for half-maximal effect: 53.1 mg/kg
Compound 4: middle estimate off by 1.9-fold (0.27 log units), on the high side, within the range that was stated.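

On the saturated chain carbon, five bonds along the chain from an aromatic nitrogen, the entering group, with 1 hydrogen-bond donor against 2 in the group it replaces, gives an at least 1.8-fold lower number from compound 1 to compound 4 (0.27 log units; that floor lies within the scatter). Among the compounds shown here, this is the first step readable in this assay for this change, and it shows that the same atoms, joined differently, can yield a number rather than a limit. Only a floor can be read for the step: the limit of > 100 mg/kg in this assay, at which 2 of the 4 values shown sit.

As far as these compounds go, the true size of the step remains open, as does whether it extends beyond the scatter. Also open, from the compounds shown here alone, is how a primary amine or a carboxylic acid would read out at this position.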